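Four Configurations of One Compound and Their Stability

The source may report more compounds than this note shows. Statements on the series, on what has been measured and on what is new or still open speak of the compounds shown alone.

Compound 3 `O=C(O)[C@H](CO)NC(=O)[C@H]1C[C@@H](O)CN1` is the starting point. In a physicochemical assay for metabolic stability, read by HPLC, with a stated time of 12 h, at pH 4.5 (a lower number here means that the compound disappears faster, a higher number that the compound lasts longer), compound 3 gives > 12 h, which is a limit of the assay and not a number. Compound 1 `O=C(O)[C@H](CO)NC(=O)[C@H]1C[C@H](O)CN1` has the same atoms and bonds in another configuration. In this assay compound 1 gives > 12 h, again a limit. Compound 2 `O=C(O)[C@@H](CO)NC(=O)[C@H]1C[C@@H](O)CN1` is a third configuration of the same atoms. In this assay compound 2 gives > 12 h, also a limit. Because of the limit of > 12 h in this assay, at which 3 of the 3 values shown sit, none of the steps between the measured compounds can be sized: a step that the two limits leave unreadable from compound 1 to compound 2, a step that the two limits leave unreadable from compound 1 to compound 3 and a step that the two limits leave unreadable from compound 2 to compound 3 are all unreadable. Compound 4 `O=C(O)[C@H](CO)NC(=O)[C@@H]1C[C@@H](O)CN1` is a fourth configuration, not yet measured. It differs from compound 3 as follows: the two compounds have the same atoms and bonds and differ only in configuration as drawn: 1 of 3 stereo elements differ; a stereocentre at a saturated ring carbon is drawn R in compound 3 and S in compound 4. Every measured step was likewise a change of configuration alone, and each left the value at the limit, so no readable change is expected here either. The expected step is a step that the limit leaves unreadable from compound 3 to compound 4. Compound 4 is therefore estimated to give 14 h, between 8 h and 30 h, and most likely to be reported once more as a limit rather than as a number.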

Compound 4, half-life: > 12 h
Compound 4: no number, only a limit; the forecaster's own chance of this, stated with the estimate: 85%; the middle value is on the limit's open side.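

In this assay compound 4 gives > 12 h, which is a limit and not a number. Among the compounds shown here, no step linking compound 4 with compound 1, compound 2 or compound 3 can be read, because all four compounds share one limit: the limit of > 12 h in this assay, at which 4 of the 4 values shown sit. The compounds shown leave open how long each configuration actually lasts, and whether configuration changes that time at all.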